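Trypsin series: sulfonyl aryl variation on a shared core

The source may hold more compounds than are shown below. What is called first, only, known or untested is meant among the compounds shown, and "the series" means these compounds.

Measured compounds:
compound 1 `CCOc1cc(C(Nc2ccc3c(N)nccc3c2)C(=O)NS(=O)(=O)c2cccc(CO)c2)ccc1OC(C)C`: > 5000 nM
compound 2 `CCOc1cc(C(Nc2ccc3c(N)nccc3c2)C(=O)NS(=O)(=O)c2cccc(N)c2)ccc1OC(C)C`: > 5000 nM
compound 3 `CCOc1cc(C(Nc2ccc3c(N)nccc3c2)C(=O)NS(=O)(=O)c2ccc(O)cc2)ccc1OC(C)C`: > 5000 nM

In an assay on isolated protein for inhibition of Trypsin (Homo sapiens) (a lower number here means a stronger inhibitor, a higher number a weaker inhibitor), compound 1 gives only a limit, > 5000 nM, and not a number. Compound 2 likewise gives only a limit in this assay, > 5000 nM. Compound 3 too gives only a limit, > 5000 nM. The three steps that relate them, a step that the two limits leave unreadable from compound 1 to compound 2, a step that the two limits leave unreadable from compound 1 to compound 3 and a step that the two limits leave unreadable from compound 2 to compound 3, are therefore unreadable in size and direction, because of the limit of > 5000 nM in this assay, at which 3 of the 3 values shown sit.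

The unmeasured compound 4 `CCOc1cc(C(Nc2ccc3c(N)nccc3c2)C(=O)NS(=O)(=O)c2ccc(N)cc2)ccc1OC(C)C` differs from compound 1 by 4-aminophenyl in place of 3-(hydroxymethyl)phenyl on a sulfonyl sulfur. The change keeps the aryl ring on the sulfonyl sulfur and swaps one donor-acceptor substituent for another, as the counted difference shows. Among the compounds with values here, the steps that bear on it, a step that the two limits leave unreadable from compound 1 to compound 2 and a step that the two limits leave unreadable from compound 1 to compound 3, give no readable size, so no step beyond the scatter can be predicted in either direction for this assay. Compound 4 is therefore expected to sit at the same limit, with an estimate of 10000 nM and a range from 5000 nM to 40000 nM. The expected step is a step that the limit leaves unreadable from compound 1 to compound 4.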

Compound 4, inhibition constant: > 5000 nM
Compound 4 gave a limit, no number (the forecaster's own chance of this, stated with the estimate: 90%); the middle value does not contradict the limit.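

In this assay compound 4 gives only a limit, > 5000 nM. Its steps from compound 1, compound 2 and compound 3 cannot be read, because the values share one limit: the limit of > 5000 nM in this assay, at which 4 of the 4 values shown sit.

The compounds shown leave open what number any of compound 1, compound 2, compound 3 and compound 4 would give in this assay, and so whether the aryl group on the sulfonyl sulfur matters there at all.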